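The source may report more compounds than this note shows. Statements on the series, on what has been measured and on what is new or still open speak of the compounds shown alone.

Three compounds share one core and differ only in the group on the amide-type nitrogen. In a functional assay on the whole organism (strain Wistar) for inhibition, with Rattus norvegicus as the target, read by paw edema, with a stated time of 4 h, at a dose of 100 mg/kg (a higher number here means more inhibition at the dose given (going by the name of the read-out), a lower number less inhibition), compound 1 `COc1cc2c(cc1OC)C(CC(=O)Nc1ccccc1)CC2` gives 37.5%, compound 2 `COc1cc2c(cc1OC)C(CC(=O)Nc1ccc(Cl)cc1)CC2` gives 60.9%, and compound 3 `COc1cc2c(cc1OC)C(CC(=O)Nc1ccccn1)CC2` gives 29.7%. Compound 3 thus sits within the scatter of compound 1, the difference being a number 7.8 percentage points lower from compound 1 to compound 3 (within the scatter), while it lies clearly under compound 2, the difference being a number 31.2 percentage points lower from compound 2 to compound 3 (beyond the scatter).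

Compound 4 `COc1cc2c(cc1OC)C(CC(=O)Nc1ccncc1)CC2` is built from compound 3 by moving the ring nitrogen: pyridin-4-yl in place of pyridin-2-yl on an amide-type nitrogen. The two structures hold the same atoms, joined differently.

Which measured steps speak to this change? None of them swaps one pyridinyl for another. The step from compound 1 to compound 3, the only one that puts a pyridinyl in place of phenyl, stayed within the scatter. The step from compound 2 to compound 3 was large, but it removed a chloro as well, as the step of a number 23.4 percentage points higher from compound 1 to compound 2 (beyond the scatter) shows on its own. So there is no measured ground for expecting compound 4 to move beyond the scatter in this assay in either direction.

Compound 4 is therefore expected to give about 32% in this assay, within a range from 18% to 48%, an expected step of a number 2.3 percentage points higher from compound 3 to compound 4 (within the scatter).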

Compound 4, a percentage reported as inhibition, in the whole organism at one dose (the size of the read-out at that dose, not a potency): 45.3%
Compound 4: middle estimate off by 13.3 percentage points, on the low side, and the stated range covers the measured number.
By their numbers in this assay, from the lowest: compounds 3, 1 and 4 (each within the scatter of the next, the first and the last beyond it); then compound 2.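

Where the ring nitrogen sits on this amide-type nitrogen substituent matters, even though the atoms stay the same: in this assay there is a number 15.6 percentage points higher from compound 3 to compound 4 (beyond the scatter), so the two pyridinyl groups can be told apart although they count alike in heavy atoms, donors and acceptors. Neither pyridinyl group separates from plain phenyl, since there is only a number 7.8 percentage points higher from compound 1 to compound 4 (within the scatter), which joins the earlier step from phenyl to pyridin-2-yl in staying small, while 4-chlorophenyl keeps its lead over pyridin-4-yl with a number 15.6 percentage points lower from compound 2 to compound 4 (beyond the scatter). Nothing available here explains why the position of the ring nitrogen changes the read-out.

The compounds shown leave open where pyridin-3-yl would fall relative to the two pyridinyl groups, and whether a chloro placed on the pyridin-4-yl ring would raise the number as it did on phenyl. They also leave open whether other groups on phenyl, such as fluoro, methoxy or a carboxylic acid, would match 4-chlorophenyl, and whether these differences would hold at other doses.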